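A few compounds are considered here, and "the series" means these few. Any claim that something is new, unique, unknown or untested is made for them only; others in the source may bear on it.

The measurements come from an ADME assay on MRC5 cells (Homo sapiens) for cytotoxicity, read by MTT assay, with a stated time of 48 h; on this read-out higher numbers stand for weaker inhibition and lower numbers for stronger inhibition.

Compound 1 `CCCC1(CO[C@@H]2O[C@@H]3CO[C@H](c4ccccc4)O[C@@H]3[C@H](OCc3ccccc3)[C@H]2OCc2ccccc2)CN1S(=O)(=O)c1ccc(C)cc1` gives 793000 nM.
Compound 2 `Cc1ccc(S(=O)(=O)N2CC2(CO[C@@H]2O[C@@H]3CO[C@H](c4ccccc4)O[C@@H]3[C@H](OCc3ccccc3)[C@H]2OCc2ccccc2)c2ccccc2)cc1` gives 570000 nM.
Compound 3 `Cc1ccc(S(=O)(=O)N2CC2(C)CO[C@@H]2O[C@@H]3CO[C@H](c4ccccc4)O[C@@H]3[C@H](OCc3ccccc3)[C@H]2OCc2ccccc2)cc1` gives > 1000000 nM, which is a limit of this assay and not a number (the limit of > 1000000 nM in this assay, at which 1 of the 3 values shown sits).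

Of the two plain numbers, compound 1 holds the higher one, yet its step to compound 2 lies within the scatter, so the two cannot be told apart. The third value is only a limit, so compound 1 is not the top of anything settled here.

Compound 4 `CCCCCCCCCCCCCCC1(CO[C@@H]2O[C@@H]3CO[C@H](c4ccccc4)O[C@@H]3[C@H](OCc3ccccc3)[C@H]2OCc2ccccc2)CN1S(=O)(=O)c1ccc(C)cc1` differs from compound 1 by undecyl in place of hydrogen on a saturated chain carbon, three bonds along the chain from a saturated ring carbon. Within the data shown here, two measured steps touch this same saturated chain. Replacing propyl by phenyl reads a 1.4-fold lower number from compound 1 to compound 2 (0.14 log units; within the scatter), within the scatter. Shortening ethyl to hydrogen reads an at least 1.2-fold higher number from compound 1 to compound 3 (0.10 log units; that floor lies within the scatter), a floor that also lies within the scatter. Among the measured compounds shown here, neither change on this chain moved this assay beyond its noise, so a much longer chain is expected to leave it in the same region, with wider uncertainty because no measured compound carries anything as long as undecyl.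

The step from compound 1 to compound 4 is therefore estimated at a 1.6-fold lower number from compound 1 to compound 4 (0.20 log units; within the scatter). Compound 4 is expected to give about 500000 nM, somewhere between 120000 nM and 1000000 nM.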

Compound 4, half-maximal inhibitory concentration: 1000000 nM
The estimate for compound 4 lay 2.0-fold (0.30 log units) below the measured number; measured number inside the range.
By their numbers in this assay, from the lowest: compounds 2, 1 and 4 (each within the scatter of the next).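

In this assay, putting undecyl in place of hydrogen on the saturated chain carbon, three bonds along the chain from a saturated ring carbon, reads as a 1.3-fold higher number from compound 1 to compound 4 (0.10 log units; within the scatter), so compound 1 and compound 4 cannot be told apart. The earlier steps shown here showed only that swapping propyl for phenyl or shortening the chain left the read-out within its usual noise; compound 4 adds that this position also accepts a far longer unbranched chain, with no measurable change in the read-out for cytotoxicity in these cells. Compound 3 remains a limit and not a number, so its place relative to compound 4 cannot be read: the limit of > 1000000 nM in this assay, at which 1 of the 4 values shown sits.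

Whether an amine or a carboxylic acid in place of undecyl would shift the number remains open, since every group shown at this position is built from carbon and hydrogen alone. From the compounds shown here alone, a chain of middle length, such as hexyl, is also absent, so it is unknown whether the read-out stays flat all the way from propyl to undecyl.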